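This account rests on a few compounds, and the source may have more. Where it says the series, first, only, none or still open, it means among the compounds named here.

Measured in a functional assay on HepG2 cells (Homo sapiens) for antiproliferative activity, read by XTT assay, with a stated time of 72 h; on this read-out lower numbers stand for stronger inhibition and higher numbers for weaker inhibition:
Compound 1 `CSc1ncnc2c1c(-c1ccoc1)cn2[C@@H]1O[C@H](CO)[C@@H](O)[C@H]1O`: > 15000 nM
Compound 2 `CSc1ncnc2c1c(-c1cccs1)cn2[C@@H]1O[C@H](CO)[C@@H](O)[C@H]1O`: > 20000 nM

Compound 2 gives > 20000 nM, which is a limit of this assay and not a number. Compound 1 gives > 15000 nM, which is also a limit. Going by the values given here, no measured compound therefore has a numerical value, and compound 2 cannot be ranked.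

The next compound, compound 3 `CSc1ncnc2c1c(-c1ccsc1)cn2[C@@H]1O[C@H](CO)[C@@H](O)[C@H]1O`, differs from compound 2 as follows: thiophen-3-yl in place of thiophen-2-yl on an aromatic carbon. In words, thiophen-3-yl stands in place of thiophen-2-yl on an aromatic carbon, and the two compounds have the same atoms, joined differently.

Among the compounds with values here, only one measured step bears on this change, a swap of group on the same carbon: a step that the two limits leave unreadable from compound 1 to compound 2. Its size cannot be read, so it gives no measure of how far such a swap moves the read-out. With only limits to go on, no step beyond the scatter is expected, and this assay will probably report a limit again. The estimated step is a number no higher from compound 2 to compound 3 (the limit leaves the size open). For compound 3 the expected value is 20000 nM, with an estimated range from 6000 nM to 40000 nM.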

Compound 3, half-maximal inhibitory concentration: > 15000 nM
Compound 3 was reported as a limit; the forecaster's own chance of this, stated with the estimate: 80%; the middle value lies beyond the limit too.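

In this assay compound 3 gives > 15000 nM, a limit and not a number. Compound 2 gives > 20000 nM, also a limit. Compound 1 gives > 15000 nM, again a limit. Going by these compounds alone, no step among compound 1, compound 2 and compound 3 can be read. The compounds shown leave open how furan-3-yl, thiophen-2-yl and thiophen-3-yl rank in this assay.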